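The source may hold more compounds than are shown below. What is called first, only, known or untested is meant among the compounds shown, and "the series" means these compounds.

Measured in an assay on mitochondria from L6 cells (Rattus norvegicus) for activation, with a stated time of 90 min; a higher number here means that more compound is needed for the effect, a lower number that less compound is needed:
compound 1 `Oc1nc2nonc2nc1Nc1ccc(OCCCC(F)(F)F)c(C(F)(F)F)c1` gives 2100 nM
compound 2 `Oc1nc2nonc2nc1Nc1ccccc1` gives 66700 nM
compound 3 `Oc1nc2nonc2nc1Nc1cccc(F)c1` gives 31200 nM

Compound 3 stands second highest of these three numbers, nearest to compound 2 and furthest from compound 1. Compound 4 `Oc1nc2nonc2nc1Nc1cccc(C(F)(F)F)c1` is not yet measured in this assay; it differs from compound 3 by trifluoromethyl in place of fluoro on an aromatic carbon. For the measured compounds named here, the one measured step that bears on this change is a 2.1-fold lower number from compound 2 to compound 3 (0.33 log units; beyond the scatter), where fluoro entered in place of hydrogen. Going by the values given here, no measured pair sets trifluoromethyl against fluoro alone; compound 1 carries trifluoromethyl together with a further chain and gives the lowest number, so its value cannot be split into parts. A modest further lowering is therefore expected, with wide uncertainty, as a 2.6-fold lower number from compound 3 to compound 4 (0.41 log units; beyond the scatter). Compound 4 is estimated at 12000 nM, within 4000 nM to 35000 nM.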

Compound 4, half-maximal effective concentration: 13300 nM
Compound 4: the middle estimate sits 1.1-fold (0.04 log units) below what was measured; low and high end bracket the measured number.
By their numbers in this assay, from the lowest: compound 1; then compound 4; then compound 3; then compound 2.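

In this assay, trifluoromethyl on this aromatic carbon gives a 2.3-fold lower number from compound 3 to compound 4 (0.37 log units; beyond the scatter) and, set against hydrogen, a 5.0-fold lower number from compound 2 to compound 4 (0.70 log units; beyond the scatter), so it lowers the number further than fluoro does. With hydrogen in place of 4,4,4-trifluorobutoxy the series shows a 6.3-fold higher number from compound 1 to compound 4 (0.80 log units; beyond the scatter), so trifluoromethyl alone does not reach the low number of compound 1. Nothing available explains these steps.

Open, from the compounds shown here alone, is how other groups on this carbon, such as a nitrile, an amine or a carboxylic acid, compare with trifluoromethyl. Also open, going by these compounds, is what 4,4,4-trifluorobutoxy gives without trifluoromethyl.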